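Replacing a hydroxyphenyl with a nitrophenyl: tolerability expected unchanged

The compounds below may be only part of what the source reports. "The series", "measured", "known", "first", "only" and "open" are said of these compounds alone.

Three compounds have been measured in an ADME assay on Vero cells (Chlorocebus sabaeus) for cytotoxicity, read by MTT assay, with a stated time of 72 h; a higher number here means that more compound is tolerated, a lower number that less compound is tolerated:

Compound 1 `C/C(=N/NC(=S)N(Cc1ccccc1)Cc1ccccc1)c1ccc(O)cc1` gives 160000 nM.
Compound 2 `C/C(=N/NC(=S)N(Cc1ccccc1)Cc1ccccc1)c1ccccc1O` gives 160000 nM.
Compound 3 `C=CCN(CC=C)C(=S)N/N=C(/C)c1ccc(F)cc1` gives 214000 nM.

Compound 2 stands level with compound 1; together they hold the lowest number of the three, and compound 3 lies within the scatter of both, so no ranking among them can be claimed. Among the compounds with values here, the single measured step that alters one place, no change at the digits printed from compound 1 to compound 2 (within the scatter), shows that moving the hydroxyl from one position on the phenyl to another left the read-out where it was.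

Compound 4 `C/C(=N/NC(=S)N(Cc1ccccc1)Cc1ccccc1)c1ccc([N+](=O)[O-])cc1` is the next to be measured. Its change from compound 2 is 4-nitrophenyl in place of 2-hydroxyphenyl on a carbon with a double bond to nitrogen. Within the data shown here, that step bears on the same ring as the one measured step, but no measured compound carries a nitro group, so the direction of any effect has no precedent here. The measured step was flat, and the whole set spans a span within the scatter, so the expectation for compound 4 in this assay is likewise no step beyond the scatter: the expected step is no change at the digits printed from compound 2 to compound 4 (within the scatter). Compound 4 is therefore estimated at 160000 nM, with a range from 60000 nM to 400000 nM.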

Compound 4, half-maximal cytotoxic concentration: < 150000 nM
Compound 4: no number, only a limit (the forecaster's own chance of this, stated with the estimate: 20%); middle value at least 1.0-fold (0.02 log units) away from the limit.
By their numbers in this assay, from the lowest: compounds 1, 2 and 3 (each within the scatter of the next). At a limit, below all of these: compound 4.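

In this assay compound 4 gives < 150000 nM, which is a limit of the assay and not a number, and the only such value among those shown: the limit of < 150000 nM in this assay, at which 1 of the 4 values shown sits. Setting the ring change against both hydroxyphenyl compounds gives an at least 1.0-fold lower number from compound 2 to compound 4 (0.02 log units; that floor lies within the scatter), and, for nitro in place of hydroxy on an aromatic carbon alone, an at least 1.0-fold lower number from compound 1 to compound 4 (0.02 log units; that floor lies within the scatter). The earlier compounds showed only that moving the hydroxyl left the read-out in place, whereas this is the first replacement of the hydroxyl by a different group on this ring, and it yields a limit rather than a number that can be set beside the others, with both floors still inside the scatter, so a real shift in tolerability is neither shown nor ruled out.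

From the compounds shown here alone, how far compound 4 truly lies from compound 1 and compound 2 remains unknown, and a measured number under the limit would be needed to settle it. Also open, going by these compounds, is whether an amine or a carboxylic acid in place of the nitro on the same ring would stay level with the hydroxyphenyl compounds.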